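From 2-ethoxyphenyl to 4-methylphenyl on a shared core

The compounds below may be only part of what the source reports. "The series", "measured", "known", "first", "only" and "open" are said of these compounds alone.

In a functional assay on MGC-803 cells (Homo sapiens) for inhibition, read by sulforhodamine B assay (on this read-out lower numbers stand for stronger inhibition and higher numbers for weaker inhibition), three compounds on a shared core have been measured so far. Compound 1 `CCCc1ccc(NC2=CC(=O)c3nc4n(c3C2=O)[C@H]2OC[C@@H](O)[C@H]2OC4)cc1` gives 1560 nM as its value. Compound 2 `O=C1C=C(Nc2ccc(C(F)(F)F)cc2)C(=O)c2c1nc1n2[C@H]2OC[C@@H](O)[C@H]2OC1` gives 2820 nM as its value. Compound 3 `CCOc1ccccc1NC1=CC(=O)c2nc3n(c2C1=O)[C@H]1OC[C@@H](O)[C@H]1OC3` gives 2450 nM as its value, which cannot be separated from the other two: the steps reaching it are a 1.6-fold higher number from compound 1 to compound 3 (0.20 log units; within the scatter) and a 1.2-fold lower number from compound 2 to compound 3 (0.06 log units; within the scatter) as measured.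

Compound 4 `Cc1ccc(NC2=CC(=O)c3nc4n(c3C2=O)[C@H]2OC[C@@H](O)[C@H]2OC4)cc1` differs from compound 3 in one place, with 4-methylphenyl in place of 2-ethoxyphenyl on an amine nitrogen as the counted change, which is 4-methylphenyl in place of 2-ethoxyphenyl on an amine nitrogen. For the measured compounds named here, two measured steps bear on this. One is a 1.6-fold higher number from compound 1 to compound 3 (0.20 log units; within the scatter) for 2-ethoxyphenyl in place of 4-propylphenyl on an amine nitrogen. The other is a 1.8-fold higher number from compound 1 to compound 2 (0.26 log units; within the scatter) for trifluoromethyl in place of propyl on an aromatic carbon. Neither leaves the scatter, so no step beyond it is expected in this assay for this change. The expected step is a 1.2-fold lower number from compound 3 to compound 4 (0.09 log units; within the scatter) on this estimate. Compound 4 is estimated at 2000 nM with an expected range from 900 nM to 4500 nM in that read-out.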

Compound 4, half-maximal inhibitory concentration: 1420 nM
Compound 4: the middle estimate sits 1.4-fold (0.15 log units) above what was measured, and the stated range covers the measured number.
By their numbers in this assay, from the lowest: compounds 4, 1, 3 and 2 (each within the scatter of the next).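

In this assay, 4-methylphenyl in place of 2-ethoxyphenyl on the amine nitrogen gives a 1.7-fold lower number from compound 3 to compound 4 (0.24 log units; within the scatter), so this change does not separate the two compounds. The smaller group also leaves the read-out unmoved against the other two compounds: methyl in place of trifluoromethyl gives a 2.0-fold lower number from compound 2 to compound 4 (0.30 log units; within the scatter), and hydrogen in place of ethyl on the chain gives a 1.1-fold lower number from compound 1 to compound 4 (0.04 log units; within the scatter). With compound 4 added, all four aryl groups on the amine nitrogen remain within the scatter of one another, so the shared core shows no measurable preference among them here.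

On these data alone, whether a carboxylic acid, an amine or a much longer chain on this aromatic ring would produce a step beyond the scatter remains open. Nothing measured here offers an explanation for these small differences.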